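Triazole aryl substituents in the spiro-oxindole series: bromo to trifluoromethyl

A few compounds are considered here, and "the series" means these few. Any claim that something is new, unique, unknown or untested is made for them only; others in the source may bear on it.

Measured so far:
compound 1 `Cc1cccc(-n2nncc2CN2C(=O)C3(C(C#N)=C(N)Oc4c(N)cc5nc6ccccc6nc5c43)c3ccccc32)c1`, 12300 nM
compound 2 `N#CC1=C(N)Oc2c(N)cc3nc4ccccc4nc3c2C12C(=O)N(Cc1cnnn1-c1ccccc1Cl)c1ccccc12`, 29800 nM
compound 3 `N#CC1=C(N)Oc2c(N)cc3nc4ccccc4nc3c2C12C(=O)N(Cc1cnnn1-c1cccc(Br)c1)c1ccccc12`, 18900 nM

All three share one core and differ only in the aryl group on the triazole nitrogen, read in a functional assay on A549 cells (Homo sapiens) for antiproliferative activity, read by MTT assay, with a stated time of 48 h; a lower number here means a stronger inhibitor, a higher number a weaker inhibitor. Going by the values given here, the one step beyond the scatter is a 2.4-fold higher number from compound 1 to compound 2 (0.38 log units; beyond the scatter). Compound 3 sits within the scatter of both neighbours: a 1.5-fold higher number from compound 1 to compound 3 (0.19 log units; within the scatter) and a 1.6-fold lower number from compound 2 to compound 3 (0.20 log units; within the scatter).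

Compound 4 `N#CC1=C(N)Oc2c(N)cc3nc4ccccc4nc3c2C12C(=O)N(Cc1cnnn1-c1cccc(C(F)(F)F)c1)c1ccccc12` is the next member. Its change from compound 3 is trifluoromethyl in place of bromo on an aromatic carbon, that is, 3-bromophenyl to 3-(trifluoromethyl)phenyl. The two steps that bear on it, from compound 1 to compound 3 and from compound 2 to compound 3, were both within the scatter, so no shift beyond the scatter is expected in this assay. Compound 4 is estimated at 18000 nM, range 9000 nM to 36000 nM, an expected step of a 1.1-fold lower number from compound 3 to compound 4 (0.02 log units; within the scatter).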

Compound 4, half-maximal inhibitory concentration: 5400 nM
Compound 4: middle estimate off by 3.3-fold (0.52 log units), on the high side; measured number below the stated range.
By their numbers in this assay, from the lowest: compound 4; then compounds 1, 3 and 2 (each within the scatter of the next, the first and the last beyond it).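

In this assay the substituent on the aryl group at the triazole nitrogen can move the number beyond the scatter: trifluoromethyl in place of bromo gives a 3.5-fold lower number from compound 3 to compound 4 (0.54 log units; beyond the scatter) while bromo in place of methyl stayed within it. The other two comparisons agree, with a 2.3-fold lower number from compound 1 to compound 4 (0.36 log units; beyond the scatter) and a 5.5-fold lower number from compound 2 to compound 4 (0.74 log units; beyond the scatter) as well, so compound 4 is the most potent of the four. Nothing at hand accounts for this shift.

As far as these compounds go, whether it is particular to trifluoromethyl remains open. A methoxy group, an amine or a carboxylic acid on the same aromatic carbon would test that.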